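Removing a Methyl from the Phenol Oxygen of Compound 2

This account rests on a few compounds, and the source may have more. Where it says the series, first, only, none or still open, it means among the compounds named here.

Of the compounds shown here, two sharing one core have been tested in a functional assay on HT-29 cells (Homo sapiens) for cytotoxicity, read by sulforhodamine B assay, with a stated time of 48 h, tested at 1 uM; a lower number here means a stronger effect, a higher number a weaker effect of the compound at the concentration tested. Compound 1, with the structure `Cc1cc(O)cc(-c2nn(CC#N)cc2-c2ccnc(-c3ccc(Oc4ccccc4)cc3)c2)c1`, gives -65% in this assay. Compound 2, with the structure `COc1cc(C)cc(-c2nn(CC#N)cc2-c2ccnc(-c3ccc(N(C)C)cc3)c2)c1`, gives -29% in this assay. Compound 2 therefore stands at the higher, weaker end of the two numbers, and its gap to compound 1 lies beyond the usual scatter; since the two structures differ in two places at once, their values alone say nothing about either change on its own.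

Compound 3, with the structure `Cc1cc(O)cc(-c2nn(CC#N)cc2-c2ccnc(-c3ccc(N(C)C)cc3)c2)c1`, has not yet been measured. It arises from compound 2 by one change: hydrogen in place of methyl on an oxygen on an aromatic ring. Among the compounds with values here, this is a small change, the loss of a single carbon on an oxygen on an aromatic ring, and no directly comparable pair has been measured.

A modest step toward a lower number is expected for compound 3, of about a number 11 percentage points lower from compound 2 to compound 3 (beyond the scatter) in this assay. Compound 3 is therefore estimated at -40%, within a range from -70% to -10%.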

Compound 3, a percentage reported as activity, at one concentration (the size of the read-out at that concentration, not a potency): 24%
Beside the measured number, compound 3's estimate is 64 percentage points below it; the measured number lies above the stated range.
By their numbers in this assay, from the lowest: compound 1; then compound 2; then compound 3.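

In this assay, the methyl on the oxygen proves far from a minor detail. With the dimethylamino group held fixed, going from methoxy to hydroxy gives a number 53 percentage points higher from compound 2 to compound 3 (beyond the scatter), so in this pair the loss of that one carbon weakens the effect, and the sign of the read-out changes as well. The second pair keeps the 3-hydroxy-5-methylphenyl group and shows that the other place counts too: dimethylamino in place of phenoxy gives a number 89 percentage points higher from compound 1 to compound 3 (beyond the scatter), so the hydroxy group alone does not bring the low number seen for compound 1. No measurement at hand explains why either change acts as it does.

These pairs leave open whether the step from methoxy to hydroxy would keep its direction and size with phenoxy in place of dimethylamino, since each step has been read against a single partner only. They also leave open what a different group on that oxygen would give, such as ethyl or a longer chain, or what an amine standing directly in place of the hydroxy would do.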